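A few compounds are considered here, and "the series" means these few. Any claim that something is new, unique, unknown or untested is made for them only; others in the source may bear on it.

Measured compounds:

compound 1 `COc1ccccc1C(=O)Nc1c[nH]nc1C(=O)N[C@H]1CC[C@H](OC)CC1` — 1500 nM
compound 2 `COc1cccc(OC)c1C(=O)Nc1c[nH]nc1C(=O)NN1CCOCC1` — > 50000 nM
compound 3 `COc1cccc(OC)c1C(=O)Nc1c[nH]nc1C(=O)NC1CCN(Cc2ccccc2)C1` — 38000 nM

In an ADME assay on MRC5 cells (Homo sapiens) for inhibition, with a stated time of 72 h (a higher number here means that more compound is needed for the effect, a lower number that less compound is needed), compound 1 gives 1500 nM, the lowest of the two numbers shown, so the least compound is needed for the effect among them. Compound 3 gives 38000 nM in this assay, a gap that lies beyond the usual scatter. Compound 2 reaches only a limit of this assay, > 50000 nM, and no number; the limit of > 50000 nM in this assay, at which 1 of the 3 values shown sits, records this.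

The step of interest leads from compound 1 to compound 4 `CO[C@H]1CC[C@H](NC(=O)c2n[nH]cc2NC(=O)C2CCC(F)(F)CC2)CC1`, which is still to be measured. The change is 4,4-difluorocyclohexyl in place of 2-methoxyphenyl on a carbonyl carbon. Here the aromatic ring leaves and a non-aromatic ring with two fluorines enters, while the rest of the molecule, including the amide and the shared core, stays the same. Going by the values given here, no measured pair shows this exact exchange, so the expectation rests on compound 1 alone.

Compound 4 is expected to give about 3000 nM, with a likely range from 700 nM to 15000 nM. The expected step from compound 1 to compound 4 is a 2.0-fold higher number from compound 1 to compound 4 (0.30 log units; within the scatter), modest and toward a somewhat higher number, with wide uncertainty.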

Compound 4, half-maximal effective concentration: > 50000 nM
Compound 4: only a limit was reported (the forecaster's own chance of this, stated with the estimate: 10%); at least 16-fold (1.22 log units) between middle value and limit.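

In this assay, the group on this carbonyl carbon now has a step of its own: with 4,4-difluorocyclohexyl in place of 2-methoxyphenyl, the result is an at least 33-fold higher number from compound 1 to compound 4 (1.52 log units; beyond the scatter), a large change. Both groups are six-membered rings with the same count of heavy atoms, so in this assay the position does not treat these two rings alike. Compound 4 gives > 50000 nM, which is a limit and not a number, and it shares that limit with one other compound: the limit of > 50000 nM in this assay, at which 2 of the 4 values shown sit.

Going by these compounds, it remains open whether the loss of the aromatic ring or the arrival of the two fluorines matters more, and a plain cyclohexyl group on this carbonyl carbon would help separate the two. On these data alone, how far compound 4 truly lies from compound 1 also stays open.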